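The compounds below may be only part of what the source reports. "The series", "measured", "known", "first", "only" and "open" are said of these compounds alone.

Measured compounds in a functional assay on FM3A cells (Mus musculus) for antiproliferative activity; on this read-out lower numbers stand for stronger inhibition and higher numbers for weaker inhibition:
compound 1 `COc1cc(C(=O)c2sc(-c3ccc(Br)cc3)cc2N)cc(OC)c1OC`, compound 1 gives 150 nM;
compound 2 `COc1cc(C(=O)c2sc(-c3ccc(Cl)cc3)cc2N)cc(OC)c1OC`, compound 2 gives 90 nM;
compound 3 `COc1cc(C(=O)c2sc(-c3ccsc3)cc2N)cc(OC)c1OC`, compound 3 gives 3.7 nM.

Compound 2 stands second highest of the three numbers in this assay. Its nearest neighbour is compound 1, with a 1.7-fold lower number from compound 1 to compound 2 (0.22 log units; within the scatter), a change that chloro in place of bromo on an aromatic carbon does not move beyond the scatter. Its furthest neighbour is compound 3, reached by a 24-fold lower number from compound 2 to compound 3 (1.39 log units; beyond the scatter); the same ring replacement from compound 1 gave a 41-fold lower number from compound 1 to compound 3 (1.61 log units; beyond the scatter).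

Compound 4 `COc1cccc(-c2cc(N)c(C(=O)c3cc(OC)c(OC)c(OC)c3)s2)c1` is not yet measured in this assay. Relative to compound 2 the change is 3-methoxyphenyl in place of 4-chlorophenyl on an aromatic carbon. Among the compounds with values here, no measured step swaps one substituted phenyl ring for another substituted phenyl ring, so the only direct guide is that the two halogen variants, compound 1 and compound 2, sit within the scatter of each other, whereas leaving the phenyl ring altogether, as in compound 3, gave the large steps noted. A methoxy-bearing phenyl ring keeps the ring type of compound 2, so the step from compound 2 to compound 4 is expected to be modest, with a lower number somewhat more likely than a higher one; the expected step is a 1.5-fold lower number from compound 2 to compound 4 (0.18 log units; within the scatter). Compound 4 is therefore estimated at 60 nM, with a range from 15 nM to 250 nM.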

Compound 4, half-maximal inhibitory concentration: 36 nM
Beside the measured number, compound 4's estimate is 1.7-fold (0.22 log units) above it; the measured number falls inside the stated range.
By their numbers in this assay, from the lowest: compound 3; then compound 4; then compounds 2 and 1 (each within the scatter of the next).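

In this assay, the position next to the ring sulfur responds to changes that keep a six-membered aromatic ring of carbon only, which the two halogen variants alone had not shown: 3-methoxyphenyl in place of 4-chlorophenyl gave a 2.5-fold lower number from compound 2 to compound 4 (0.40 log units; beyond the scatter), and 3-methoxyphenyl in place of 4-bromophenyl gave a 4.2-fold lower number from compound 1 to compound 4 (0.62 log units; beyond the scatter). Even so, this gain does not match the ring exchange seen earlier, since 3-methoxyphenyl in place of thiophen-3-yl gave a 9.7-fold higher number from compound 3 to compound 4 (0.99 log units; beyond the scatter), leaving compound 3 with the lowest number of the four. The evidence at hand offers no explanation for any of these steps.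

The compounds shown leave open whether the lower number of compound 4 belongs to the methoxy group itself or to where it sits on the phenyl ring, as the group and its location change together with the loss of the halogen. They also leave open how an ethoxy or a dimethylamino group on the same phenyl ring would compare with the 3-methoxyphenyl of compound 4.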